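Nitro in place of isopropyl: an unmeasured step

A few compounds are considered here, and "the series" means these few. Any claim that something is new, unique, unknown or untested is made for them only; others in the source may bear on it.

Compound 1 `CCc1ccc(-c2nc3c(c(C)nn3-c3ccccc3)c(-c3ccccc3I)c2C#N)cc1`: > 20000 nM, a limit of the assay
Compound 2 `CCc1ccc(-c2nc3c(c(C)nn3-c3ccccc3)c(-c3ccccc3Br)c2C#N)cc1`: > 20000 nM, a limit of the assay
Compound 3 `Cc1nn(-c2ccccc2)c2nc(-c3ccc(C(C)C)cc3)c(C#N)c(-c3ccccc3O)c12`: 22600 nM

All three compounds were tested in an ADME assay on BJ cells (Homo sapiens) for cytotoxicity, with a stated time of 72 h; a lower number here means that less compound is needed, a higher number that more compound is needed for the effect. Among the compounds with values here, compound 3 is the only one with an actual number, 22600 nM. The other two results are not numbers, and they form (the limit of > 20000 nM in this assay, at which 2 of the 3 values shown sit).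

Compound 4 `Cc1nn(-c2ccccc2)c2nc(-c3ccc([N+](=O)[O-])cc3)c(C#N)c(-c3ccccc3O)c12` differs from compound 3 in one group, with nitro in place of isopropyl on an aromatic carbon. Within the data shown here, the only measured step is a step that the two limits leave unreadable from compound 1 to compound 2. It exchanges bromo for iodo, so it offers no size to carry over to this change. The data therefore point neither up nor down, and no shift beyond the usual scatter is expected. The expected step is a 1.0-fold lower number from compound 3 to compound 4 (0.01 log units; within the scatter), anchored on compound 3 at 22600 nM. For compound 4 the estimated value is 22000 nM, with an expected range from 8000 nM to 60000 nM. The result could also turn out to be only a limit.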

Compound 4, half-maximal effective concentration: > 20000 nM
Compound 4: a limit, no number; the forecaster's own chance of this, stated with the estimate: 45%; the middle value lies beyond the limit too.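

No size can be read for the step from compound 3 to compound 4, since compound 4 gives only a limit and not a number: the limit of > 20000 nM in this assay, at which 3 of the 4 values shown sit.

The compounds shown leave open whether nitro in place of isopropyl, or bromo in place of iodo, changes the number at all, and in which direction.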